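Working notes on a small cytotoxicity series

A few compounds are considered here, and "the series" means these few. Any claim that something is new, unique, unknown or untested is made for them only; others in the source may bear on it.

Measured compounds:
compound 1 `COc1ccc(Nc2nc3ccccc3nc2S(=O)(=O)c2ccc(C)cc2)cc1`: > 50000 nM
compound 2 `COc1cc(Nc2nc3ccccc3nc2S(=O)(=O)c2ccc(C)cc2)cc(OC)c1`: 8060 nM
compound 3 `COc1ccc(Nc2nc3ccccc3nc2S(=O)(=O)c2ccc(OC)cc2)cc1`: 8260 nM

Three compounds have been run in a functional assay on A549 cells (Homo sapiens) for cytotoxicity, read by MTT assay, with a stated time of 72 h; a lower number here means a stronger inhibitor, a higher number a weaker inhibitor. Compound 1 gives > 50000 nM, and this is a limit of the assay rather than a number (the limit of > 50000 nM in this assay, at which 1 of the 3 values shown sits). Compound 2 gives 8060 nM. Compound 3 gives 8260 nM. The values of compound 2 and compound 3 lie within the scatter of each other, so no order between them is drawn.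

The change from compound 1 to compound 2 is 3,5-dimethoxyphenyl in place of 4-methoxyphenyl on a nitrogen on an aromatic ring, and it made an at least 6.2-fold lower number from compound 1 to compound 2 (0.79 log units; beyond the scatter). The change from compound 1 to compound 3 is methoxy in place of methyl on an aromatic carbon, with an at least 6.0-fold lower number from compound 1 to compound 3 (0.78 log units; beyond the scatter). Both steps start from a limit, so each size is a bound, not a measured gap.

Compound 4 `COc1ccc(S(=O)(=O)c2nc3ccccc3nc2Nc2cc(OC)cc(OC)c2)cc1` has not yet been measured in this assay. It differs from compound 3 by 3,5-dimethoxyphenyl in place of 4-methoxyphenyl on a nitrogen on an aromatic ring. For the measured compounds named here, this is the same change as the one from compound 1 to compound 2, now made on a core that differs from the core of compound 1 by methoxy in place of methyl on an aromatic carbon. The expected step is a 3.3-fold lower number from compound 3 to compound 4 (0.52 log units; beyond the scatter), held somewhat short of the earlier bound because the step of an at least 6.2-fold lower number from compound 1 to compound 2 (0.79 log units; beyond the scatter) is itself only a bound. Compound 4 is therefore estimated at 2500 nM, with an expected range from 800 nM to 8000 nM.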

Compound 4, half-maximal inhibitory concentration: 12700 nM
Compound 4: the middle estimate sits 5.1-fold (0.71 log units) below what was measured, and the stated range ends below it.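

Carried onto the core of compound 3, 3,5-dimethoxyphenyl in place of 4-methoxyphenyl on a nitrogen on an aromatic ring gives a 1.5-fold higher number from compound 3 to compound 4 (0.19 log units; within the scatter) in this assay, so this change does not repeat the step seen on the core of compound 1: the same change on two cores in this assay, an at least 6.2-fold lower number (0.79 log units; beyond the scatter) from compound 1 to compound 2 and a 1.5-fold higher number (0.19 log units; within the scatter) from compound 3 to compound 4, at least 9.5-fold (0.97 log units) apart, beyond the scatter of two such steps
Read along the other edge of the set, methoxy in place of methyl on an aromatic carbon gives a 1.6-fold higher number from compound 2 to compound 4 (0.20 log units; within the scatter), and this change does not carry over from one core to the other either: the same change on two cores in this assay, an at least 6.0-fold lower number (0.78 log units; beyond the scatter) from compound 1 to compound 3 and a 1.6-fold higher number (0.20 log units; within the scatter) from compound 2 to compound 4, at least 9.5-fold (0.97 log units) apart, beyond the scatter of two such steps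
Compound 1 gives > 50000 nM, which is a limit of the assay, so the size of the step from compound 1 is not known in either pair; the four compounds show that the two changes do not add up here, but not why, and a single pair of cores gives no rule for the wider series.

The compounds shown leave open whether the same holds when an amine or a carboxylic acid stands in place of a methoxy group on the ring on the nitrogen. They also leave open whether a longer chain, such as ethoxy, in place of the methoxy or methyl on the other aromatic ring would behave as methoxy does on the core of compound 1 or on the core of compound 3.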